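The source may hold more compounds than are shown below. What is called first, only, known or untested is meant among the compounds shown, and "the series" means these compounds.

Compounds measured in an assay on HEK-293T cells for inhibition of diacylglycerol lipase-alpha (Homo sapiens), read by colorimetric assay (a higher number here means a weaker inhibitor, a lower number a stronger inhibitor), so far:

compound 1 `O=Cc1coc(C(=O)CCCCCCc2ccccc2)n1` — 1510 nM
compound 2 `O=C(CCCCCCc1ccccc1)c1nc(Cl)co1` — 2400 nM
compound 3 `CC(=O)c1cnc(C(=O)CCCCCCc2ccccc2)o1` — > 10000 nM, a limit of the assay, not a number

Compound 3 `CC(=O)c1cnc(C(=O)CCCCCCc2ccccc2)o1` stands apart from the other two: in this assay compound 3 gives only > 10000 nM, which is a limit of the assay and not a number (the limit of > 10000 nM in this assay, at which 1 of the 3 values shown sits). Compounds 1 and 2, by contrast, both give measured values.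

The step to compound 4 `O=C(CCCCCCc1ccccc1)c1ncc(Cl)o1` is chloro in place of acetyl on an aromatic carbon. Among the compounds with values here, the only measured step that bears on it is the one from compound 1 to compound 2, where an acyl group on an aromatic carbon of the shared core also gives way to chloro, though at a different ring position: a 1.6-fold higher number from compound 1 to compound 2 (0.20 log units; within the scatter). That step lies within the scatter, so the measured series gives no sign that the acyl-to-chloro exchange itself moves the number by much. Compound 3, however, sits at the limit, so the starting point of the present step is known only as a range, and any estimate for compound 4 in this assay must carry a wide spread.

On this basis compound 4 is expected to land near the upper end of the measured range, at about 6000 nM, between 1500 nM and 25000 nM, with a fair chance that the assay again reports only a limit. The step this implies from compound 3 to compound 4, an at least 1.6-fold lower number from compound 3 to compound 4 (0.22 log units; that floor lies within the scatter), is an expectation only.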

Compound 4, half-maximal inhibitory concentration: > 10000 nM
Compound 4 gave a limit, no number (the forecaster's own chance of this, stated with the estimate: 40%); at least 1.6-fold (0.22 log units) between middle value and limit.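

In this assay compound 4 gives > 10000 nM, a limit of the assay and not a number, and the step from acetyl to chloro cannot be read, since both of its ends are limits: the limit of > 10000 nM in this assay, at which 2 of the 4 values shown sit.

What the result adds concerns the place of the chloro rather than the exchange of groups: with 5-chloro-1,3-oxazol-2-yl in place of 4-chloro-1,3-oxazol-2-yl on the carbonyl carbon, the series shows an at least 4.1-fold higher number from compound 2 to compound 4 (0.61 log units; beyond the scatter). With 5-chloro-1,3-oxazol-2-yl in place of 4-formyl-1,3-oxazol-2-yl there is likewise an at least 6.6-fold higher number from compound 1 to compound 4 (0.82 log units; beyond the scatter), and since acetyl and chloro at the ring carbon next to the ring oxygen both end at the limit, neither group at this place gives a measured value among the compounds shown.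

On these data alone, how far compound 3 and compound 4 lie beyond the limit stays open, so any order between acetyl and chloro at this place is unknown. Also open, as far as these compounds go, is whether a hydrogen, a methyl group, a carboxylic acid or an amine at this same ring carbon would return a measured value.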